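Swapping the aryl ring of compound 1 for a cyanopyridine

This account rests on a few compounds, and the source may have more. Where it says the series, first, only, none or still open, it means among the compounds named here.

Measured compounds:
compound 1, `CC(C)OC(=O)N1CCC(Oc2ncnc3c2CCN3c2ccc(C#N)cc2F)CC1`: 134%
compound 2, `CC(C)OC(=O)N1CCC(Oc2ncnc3c2CCN3c2ccc(-c3nccs3)cc2F)CC1`: 74%
compound 3, `CC(C)OC(=O)N1CCC(Oc2ncnc3c2CCN3c2ccc(-c3cccn3C)cc2F)CC1`: 44%

In a functional assay on CHO-K1 cells with Glucose-dependent insulinotropic receptor (Homo sapiens) as the target, read by a luciferase reporter, with a stated time of 5 h (on this read-out higher numbers stand for larger maximal responses and lower numbers for smaller maximal responses), compound 1 gives 134%, the highest of the three numbers; compound 2 comes nearest, and compound 3 lies furthest. The measured steps were a number 60 percentage points lower from compound 1 to compound 2 (beyond the scatter) and a number 90 percentage points lower from compound 1 to compound 3 (beyond the scatter), with a number 30 percentage points lower from compound 2 to compound 3 (beyond the scatter) between the two heteroaryl compounds. All three exchange the group that replaces the cyano on the aromatic carbon. Compound 4, `CC(C)OC(=O)N1CCC(Oc2ncnc3c2CCN3c2ccc(C#N)cn2)CC1`, differs from compound 1 in another way: 5-cyanopyridin-2-yl in place of 4-cyano-2-fluorophenyl on a nitrogen on an aromatic ring in a ring. For the measured compounds named here, no measured step touches this ring itself, so the existing data give no direct guide; the cyano group that accompanies the highest value is kept. For compound 4 the expected value in this assay is 115%, with a range from 70% to 150%. This corresponds to an expected a number 19 percentage points lower from compound 1 to compound 4 (beyond the scatter).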

Compound 4, largest response reached (reported as percent of maximum), in percent of the reference or control that the assay uses: 105%
For compound 4 the middle estimate is 10 percentage points above the measured one; the range from low to high includes it.
By their numbers in this assay, from the lowest: compound 3; then compound 2; then compound 4; then compound 1.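

Exchanging 4-cyano-2-fluorophenyl for 5-cyanopyridin-2-yl on the nitrogen gives a number 29 percentage points lower from compound 1 to compound 4 (beyond the scatter) in this assay, so the ring itself matters at this position, and not only the group replacing the cyano, while compound 4 still reaches 105%. The fluorine leaves and a ring hetero atom enters in the same step, so their shares cannot be told apart. Nothing at hand explains the drop. Open, going by these compounds, is how a plain 4-cyanophenyl group, or a 5-cyanopyrimidin-2-yl group, would behave on this nitrogen.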